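Carbamate Oxygen Traded for Carbon in a Tracheal Antagonist Series

The source may hold more compounds than are shown below. What is called first, only, known or untested is meant among the compounds shown, and "the series" means these compounds.

Compound 1 `COc1cc(C(=O)O)ccc1Cn1ccc2ccc(NC(=O)OC3CCCC3)cc21` stands at the top of the two numbers in hand: in a functional assay on trachea for antagonist activity at cysteinyl leukotriene receptor 1 (Cavia porcellus) (a lower number here means a less potent compound, a higher number a more potent compound, by a factor of ten per unit of this negative logarithm), compound 1 gives 7.8, whereas compound 2 `CCCCOC(=O)Nc1ccc2cnn(Cc3ccc(C(=O)O)cc3OC)c2c1` gives 6.7 in this assay, a gap that lies beyond the usual scatter. The untested compound 3 `CCCCC(CC)C(=O)Nc1ccc2ccn(Cc3ccc(C(=O)O)cc3OC)c2c1` is derived from compound 1 by a single change, (1-ethylpentyl in place of cyclopentyloxy on a carbonyl carbon), so that the (cyclopentyloxycarbonyl)amino group becomes a ((1-ethylpentyl)carbonyl)amino group. For the measured compounds named here, no measured pair here traces such a step, so the direction is uncertain; the account expects a small downward step for compound 3, a number 0.30 log units lower from compound 1 to compound 3 (within the scatter), because compound 1 already sits at 7.8 and the series gives no hint of anything stronger. For compound 3 the estimate in this assay is therefore 7.5, with a plausible range from 6.8 to 8.2.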

Compound 3, negative logarithm of the antagonist equilibrium constant: 6.6
For compound 3 the middle estimate is 0.90 log units above the measured one, and the stated range ends above it.
By their numbers in this assay, from the lowest: compounds 3 and 2 (each within the scatter of the next); then compound 1.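

In this assay the group on this carbonyl carbon proves to matter, as the exchange of cyclopentyloxy for 1-ethylpentyl gives a number 1.20 log units lower from compound 1 to compound 3 (beyond the scatter) on an otherwise unchanged core. The earlier pair could not show this: compound 1 and compound 2 differ in more than one place, so no single change at this position had been traced. The exchange removes the oxygen and the ring together, and no measurement here explains the size of the step.

The compounds shown therefore do not separate the loss of the oxygen from the loss of the ring. On these data alone, a cyclopentyl group placed directly on the carbonyl carbon, or a 1-ethylpentyloxy group in the same place, would pull those two changes apart, and whether either would hold the potency of compound 1 remains open.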